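Swapping chloro for methyl on compound 1

The source may hold more compounds than are shown below. What is called first, only, known or untested is meant among the compounds shown, and "the series" means these compounds.

Compound 1 `O=C(Nc1nnc(-c2cccc(O)c2O)s1)c1ccc(Cl)cc1`: 9500 nM
Compound 2 `O=C(Nc1nnc(-c2ccc(O)c(O)c2)s1)C1CCCCC1`: 16300 nM
Compound 3 `O=C(Nc1nnc(-c2ccc(O)c(O)c2)s1)c1ccc(Cl)cc1`: 14600 nM

These three compounds were tested in a functional assay on A549 cells (Homo sapiens) for cytotoxicity, read by MTT assay, with a stated time of 72 h; on this read-out lower numbers stand for stronger inhibition and higher numbers for weaker inhibition. Compound 1, at 9500 nM, lies within the usual scatter of both compound 2 and compound 3, so these numbers cannot rank the three.

The next compound, compound 4 `Cc1ccc(C(=O)Nc2nnc(-c3cccc(O)c3O)s2)cc1`, differs from compound 1 in one place: methyl in place of chloro on an aromatic carbon. In words, this is methyl in place of chloro on an aromatic carbon, turning 4-chlorophenyl into 4-methylphenyl.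

Within the data shown here, no measured pair shows this exact swap. The closest evidence comes from the group on the carbonyl carbon, where 4-chlorophenyl in place of cyclohexyl gave a 1.1-fold lower number from compound 2 to compound 3 (0.05 log units; within the scatter). Exchanging that whole group therefore left the number within the scatter, although one step is thin evidence. On this basis, no step beyond the scatter is expected in this assay, and the direction cannot be called.

The expected change is a 1.2-fold higher number from compound 1 to compound 4 (0.06 log units; within the scatter), which is only an estimate. For compound 4, the estimated value is 11000 nM, with an expected range from 5500 nM to 22000 nM.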

Compound 4, half-maximal inhibitory concentration: 11300 nM
For compound 4 the middle estimate is 1.0-fold (0.01 log units) below the measured one; the measured number falls inside the stated range.
By their numbers in this assay, from the lowest: compounds 1, 4, 3 and 2 (each within the scatter of the next).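

Putting methyl in place of chloro on the aromatic carbon para to a large group gives a 1.2-fold higher number from compound 1 to compound 4 (0.08 log units; within the scatter) in this assay. Among these compounds, the only earlier step exchanged the whole group on the carbonyl carbon, whereas this one changes a single heavy atom on an otherwise identical compound, so it is the first direct reading of this position: here, chloro and methyl cannot be told apart. No measurement is available that would explain this result or link it to any property of the two groups.

Chloro and methyl are only two possible groups at this position, so it remains open whether an amine, a carboxylic acid or a longer chain there would move the number beyond the scatter. From the compounds shown here alone, it also remains open whether the same swap from chloro to methyl would read the same way on the core of compound 3, which carries its two hydroxyl groups in a different arrangement from compound 1.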